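Swapping the acid for a methyl amide

The source may report more compounds than this note shows. Statements on the series, on what has been measured and on what is new or still open speak of the compounds shown alone.

Compound 1 `O=C(O)c1ccc(S(=O)(=O)Nc2ccc(NS(=O)(=O)c3ccc(F)cc3)cc2)cc1` carries a carboxy group on its core. In an assay for inhibition of liver carboxylesterase 1 (Homo sapiens), read by spectrophotometry (a higher number here means a weaker inhibitor, a lower number a stronger inhibitor), compound 1 gives only > 100000 nM, a limit of the measurement rather than a number. Compound 2 `Cc1c(C)c(NS(=O)(=O)c2ccc(F)cc2)c(C)c(C)c1NS(=O)(=O)c1ccc(F)cc1` in this assay gives > 100000 nM, again a limit. Both values sit at the same point (the limit of > 100000 nM in this assay, at which 2 of the 2 values shown sit), so neither yet gives a number to build on. Compound 3 `CNC(=O)c1ccc(S(=O)(=O)Nc2ccc(NS(=O)(=O)c3ccc(F)cc3)cc2)cc1` differs from compound 1 by methylamino in place of hydroxy on a carbonyl carbon. Without a measured step as guide, the expected shift is an at least 2.5-fold lower number from compound 1 to compound 3 (0.39 log units; beyond the scatter), toward a stronger inhibitor, though the readout may again stop at a limit. Compound 3 is estimated at 40000 nM, within 4000 nM to 200000 nM.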

Compound 3, inhibition constant: > 100000 nM
Compound 3: only a limit was reported; the forecaster's own chance of this, stated with the estimate: 45%; middle value at least 2.5-fold (0.39 log units) from the limit.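

Compound 3 also stops at a limit, so no step from compound 1 to compound 3 can be read in this assay: the limit of > 100000 nM in this assay, at which 3 of the 3 values shown sit.

The compounds shown leave open which change to the shared core, if any, would give a real number.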